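Extending the chain from compound 3 to compound 4

The source may report more compounds than this note shows. Statements on the series, on what has been measured and on what is new or still open speak of the compounds shown alone.

In a functional assay on brain (Rattus norvegicus, strain Wistar) for inhibition (on this read-out higher numbers stand for weaker inhibition and lower numbers for stronger inhibition), compound 3 (`CCCCCCCCCCc1ccc(-c2c(C)[nH]c(=O)n2C2CCCCC2)cc1`) gives 27000 nM. This lies within the scatter of compound 1 (`CCCCc1ccc(-c2c(C)[nH]c(=O)n2C2CCCCC2)cc1`) at 27100 nM and of compound 2 (`CCCc1ccc(-c2c(C)[nH]c(=O)n2C2CCCCC2)cc1`) at 13900 nM. Compound 4 (`CCCCCCCCCCCCc1ccc(-c2c(C)[nH]c(=O)n2C2CCCCC2)cc1`) carries a longer chain: ethyl in place of hydrogen on a saturated chain carbon, ten or more bonds along the chain from an aromatic carbon. The three measured chain steps bear on this: a 1.9-fold lower number from compound 1 to compound 2 (0.29 log units; within the scatter), a 1.0-fold lower number from compound 1 to compound 3 (0.00 log units; within the scatter) and a 1.9-fold higher number from compound 2 to compound 3 (0.29 log units; within the scatter), all within the scatter. No step beyond the scatter is therefore expected in this assay. The expected step is no change at the digits printed from compound 3 to compound 4 (within the scatter). For compound 4 the estimate is 27000 nM, with an expected range of 12000 nM to 60000 nM.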

Compound 4, half-maximal inhibitory concentration: > 100000 nM
Compound 4: a limit, no number (the forecaster's own chance of this, stated with the estimate: 15%); middle value at least 3.7-fold (0.56 log units) away from the limit.
By their numbers in this assay, from the lowest: compounds 2, 3 and 1 (each within the scatter of the next). At a limit, above all of these: compound 4.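

In this assay compound 4 gives only a limit, not a number: the limit of > 100000 nM in this assay, at which 1 of the 4 values shown sits. Chain length at this position now matters, with an at least 3.7-fold higher number from compound 3 to compound 4 (0.56 log units; beyond the scatter), an at least 7.1-fold higher number from compound 2 to compound 4 (0.85 log units; beyond the scatter) and an at least 3.6-fold higher number from compound 1 to compound 4 (0.56 log units; beyond the scatter). Compound 1, compound 2 and compound 3 stay within the scatter of each other, so inhibition weakens only once ethyl replaces hydrogen on the decyl chain of compound 3.

On these data alone, the size of the loss past the limit stays open, and an undecyl chain would show whether it sets in gradually. As far as these compounds go, whether an amine or a carboxylic acid on the chain would restore inhibition also remains open.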